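Adding an aromatic ring back to the cyclopropyl compound

A few compounds are considered here, and "the series" means these few. Any claim that something is new, unique, unknown or untested is made for them only; others in the source may bear on it.

Compound 1 `N[C@H]1CC[C@H](Nc2nc(NCc3cccc(I)c3)c3ncn(C4CCCC4)c3n2)CC1` gives 1400 nM
Compound 2 `N[C@H]1CC[C@H](Nc2nc(NCC3CC3)c3ncn(C4CCCC4)c3n2)CC1` gives 600 nM

In a functional assay on PC-3 cells (Homo sapiens) for inhibition (a lower number here means a stronger inhibitor, a higher number a weaker inhibitor), compound 2 holds the lower of the two numbers, so it is the stronger inhibitor of this pair. Compound 3 `C[C@H](Nc1nc(N[C@H]2CC[C@H](N)CC2)nc2c1ncn2C1CCCC1)c1ccccc1` differs from compound 2 in one place, and the difference reads 1-phenylethyl in place of cyclopropylmethyl on a nitrogen on an aromatic ring in full. Here 1-phenylethyl takes the place of cyclopropylmethyl on a nitrogen on an aromatic ring, so a six-membered aromatic ring is present again, as in compound 1. Among the compounds with values here, only one measured step bears on this: a 2.3-fold lower number from compound 1 to compound 2 (0.37 log units; beyond the scatter), and it replaced an aromatic group with cyclopropyl. Within the data shown here, compound 3 goes the opposite way, though its ring carries no iodine, and no measured compound has a defined stereocentre at this carbon. In this assay the expected step is a 1.7-fold higher number from compound 2 to compound 3 (0.22 log units; within the scatter), a small move toward a higher number. Compound 3 is estimated at 1000 nM, with an expected range from 350 nM to 3000 nM in repeated measurements.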

Compound 3, half-maximal inhibitory concentration: 3900 nM
The estimate for compound 3 lay 3.9-fold (0.59 log units) below the measured number, and the stated range ends below it.
By their numbers in this assay, from the lowest: compound 2; then compound 1; then compound 3.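

In this assay, both compounds with a six-membered aromatic ring on this nitrogen give higher numbers than the cyclopropylmethyl compound, and the change to 1-phenylethyl gives a 6.5-fold higher number from compound 2 to compound 3 (0.81 log units; beyond the scatter). Removing the iodine does not bring the number down: the change from 3-iodobenzyl gives a 2.8-fold higher number from compound 1 to compound 3 (0.44 log units; beyond the scatter), although this step also swaps benzyl for 1-phenylethyl, with its defined stereocentre, so the iodine cannot be judged alone. Nothing available explains why the number rises with either change.

Going by these compounds, it remains open where an unsubstituted benzyl group or the other stereoisomer of 1-phenylethyl would fall relative to compound 1 and compound 3. On these data alone, it is also open whether a non-aromatic group larger than cyclopropylmethyl, such as cyclohexylmethyl, would stay close to compound 2.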